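Ethyl to isopropyl at the edge of the assay

The source may report more compounds than this note shows. Statements on the series, on what has been measured and on what is new or still open speak of the compounds shown alone.

Compound 3 (`CCNC(=O)c1c(NO)cc(-c2ccccc2)oc1=O`) is the starting point for this step. In an ADME assay on Huh-7 cells (Homo sapiens) for cytotoxicity, read by a luciferase reporter and WST assay, with a stated time of 3 days (a higher number here means that more compound is tolerated, a lower number that less compound is tolerated), compound 3 gives > 20000 nM, which is a limit of the assay and not a number. Compound 1 (`Cc1ccccc1NC(=O)c1c(NO)cc(-c2ccccc2)oc1=O`) gives > 20000 nM, also a limit. Compound 2 (`Cc1ccc(NC(=O)c2c(NO)cc(-c3ccccc3)oc2=O)cc1`) gives > 20000 nM, again a limit. The measurements so far therefore show only (the limit of > 20000 nM in this assay, at which 3 of the 3 values shown sit).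

Compound 4 (`CC(C)NC(=O)c1c(NO)cc(-c2ccccc2)oc1=O`) changes one small part of compound 3: methyl in place of hydrogen on a saturated chain carbon bound to an amide-type nitrogen and a saturated chain carbon. This is methyl in place of hydrogen on a saturated chain carbon bound to an amide-type nitrogen and a saturated chain carbon, so ethyl becomes isopropyl.

The closest guides are the measured swaps on that same nitrogen. They are a step that the two limits leave unreadable from compound 1 to compound 3, a step that the two limits leave unreadable from compound 2 to compound 3 and a step that the two limits leave unreadable from compound 1 to compound 2. None of them has a readable size, but 2-methylphenyl, 4-methylphenyl and ethyl all leave their compounds at the same limit. A step beyond the usual scatter, in either direction, is therefore not expected in this assay.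

The expected change is a step that the limit leaves unreadable from compound 3 to compound 4. Compound 4 is estimated at 30000 nM, with an expected range from 15000 nM to 100000 nM.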

Compound 4, half-maximal cytotoxic concentration: > 20000 nM
Compound 4 gave a limit, no number; the forecaster's own chance of this, stated with the estimate: 85%; the middle value lies beyond the limit too.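

In this assay compound 4 gives > 20000 nM as a limit of the assay and not a number. Among these compounds, no step between compound 4 and compound 1, compound 2 or compound 3 can be read, since all four compounds sit at the same limit: the limit of > 20000 nM in this assay, at which 4 of the 4 values shown sit. The compounds shown leave open how much of each is actually tolerated and whether changing the group on the amide-type nitrogen alters that amount.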